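The source may hold more compounds than are shown below. What is called first, only, known or untested is meant among the compounds shown, and "the series" means these compounds.

Compound 2, `Nc1cn([C@H]2C[C@H](O)[C@@H](CO)O2)c(=O)[nH]c1=O`, stands at the weaker end of the two numbers on record: in an assay on isolated protein for inhibition of thymidine kinase, cytosolic (Rattus norvegicus) (a lower number here means a stronger inhibitor, a higher number a weaker inhibitor), compound 2 gives 370000 nM. Among the measured compounds shown here, the only comparison available is compound 1, `CCCCCn1c(=O)c(C)cn([C@H]2C[C@H](O)[C@@H](CO)O2)c1=O`, which in this assay gives 36000 nM, a markedly lower number than that of compound 2, and the gap between the two lies beyond the scatter. For the measured compounds named here, the two structures differ in several places at once, so no single-change step connects them.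

The next compound, compound 3, `C/C=C/c1cn([C@H]2C[C@H](O)[C@@H](CO)O2)c(=O)[nH]c1=O`, is reached from compound 2 by one change: prop-1-en-1-yl in place of amino on an aromatic carbon. Going by the values given here, no measured pair shows this exact exchange, so the step has to be judged from the two values that exist. Compound 2 sits at the highest number known here, and compound 1 shows that a compound with a small carbon group on that aromatic carbon and no amino can reach a much lower number. On that basis the step from compound 2 to compound 3 is expected to be a clear drop in this assay, estimated at a 25-fold lower number from compound 2 to compound 3 (1.39 log units; beyond the scatter). Compound 3 is accordingly estimated to give 15000 nM, within a range from 3000 nM to 80000 nM.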

Compound 3, inhibition constant: 15500000 nM
Estimate against measurement, compound 3: 1000-fold (3.01 log units) below; the whole stated range lies below it.
By their numbers in this assay, from the lowest: compound 1; then compound 2; then compound 3.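

Among the compounds shown here, replacing amino with prop-1-en-1-yl on this aromatic carbon, two atoms from the ring nitrogen, gives in this assay a 42-fold higher number from compound 2 to compound 3 (1.62 log units; beyond the scatter) as the first single-place step in this set, and it runs towards weaker inhibition. For the compounds shown here, the position is therefore far from indifferent to what it carries, and a larger carbon group here, with no hydrogen-bond donor or acceptor in place of the one of each that amino brings, does not improve on amino in the one direct comparison available. Nothing measured here explains the size or the direction of this step.

Going by these compounds, one step cannot separate what is lost with amino from what is gained with prop-1-en-1-yl, so it remains open whether a saturated propyl chain, a hydroxyl group or a bromine atom on the same aromatic carbon would read closer to compound 2 or to compound 3 in this assay on this scale. Also open, on these data alone, is whether the same exchange would run the same way on a core that carries a carbon chain on the ring nitrogen.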